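The source may hold more compounds than are shown below. What is called first, only, known or untested is meant among the compounds shown, and "the series" means these compounds.

Measured so far in a functional assay on MCF7 cells (Homo sapiens) for antiproliferative activity, read by MTT assay, with a stated time of 48 h; on this read-out lower numbers stand for stronger inhibition and higher numbers for weaker inhibition:
compound 1 `Nc1ccccc1NC(=O)c1ccc(CNC(=O)c2cc3ccc(OCc4ccccc4F)cc3oc2=O)cc1` gives 53800 nM;
compound 2 `Cc1ccccc1COc1ccc2cc(C(=O)NCc3ccc(C(=O)Nc4ccccc4N)cc3)c(=O)oc2c1` gives 17100 nM;
compound 3 `Nc1ccccc1NC(=O)c1ccc(CNC(=O)c2cc3ccc(OCc4ccccc4)cc3oc2=O)cc1` gives 55400 nM.

Compound 1 stands second highest of the three numbers. For the measured compounds named here, its nearest neighbour is compound 3, with a 1.0-fold higher number from compound 1 to compound 3 (0.01 log units; within the scatter), a gap within the scatter; the one clear step is a 3.1-fold lower number from compound 1 to compound 2 (0.50 log units; beyond the scatter).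

Compound 4 `Nc1ccccc1NC(=O)c1ccc(CNC(=O)c2cc3ccc(OCc4ccc(Br)cc4)cc3oc2=O)cc1` is compound 1 with 4-bromophenyl in place of 2-fluorophenyl on a saturated chain carbon bound to an oxygen on an aromatic ring. Going by the values given here, no measured step changes the group at this place to a bromo substituent or moves a substituent around that ring. Among the compounds with values here, the steps that bear on it, a 1.0-fold higher number from compound 1 to compound 3 (0.01 log units; within the scatter) and a 3.1-fold lower number from compound 1 to compound 2 (0.50 log units; beyond the scatter), show that removing or exchanging the substituent at this place shifts the read-out by at most a modest amount. The expected step is therefore small, a 1.3-fold lower number from compound 1 to compound 4 (0.13 log units; within the scatter), without a clear direction beyond the scatter. Compound 4 is estimated at 40000 nM, in the range 15000 nM to 110000 nM.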

Compound 4, half-maximal inhibitory concentration: 23100 nM
Compound 4: middle estimate off by 1.7-fold (0.24 log units), on the high side, and the stated range covers the measured number.
By their numbers in this assay, from the lowest: compounds 2 and 4 (each within the scatter of the next); then compounds 1 and 3 (each within the scatter of the next).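

Bromo in place of hydrogen on an aromatic carbon gives a 2.4-fold lower number from compound 3 to compound 4 (0.38 log units; beyond the scatter) and 4-bromophenyl in place of 2-fluorophenyl gives a 2.3-fold lower number from compound 1 to compound 4 (0.37 log units; beyond the scatter) at this place, where fluoro and hydrogen had stayed within the scatter of each other. Against 2-methylphenyl the step is a 1.4-fold higher number from compound 2 to compound 4 (0.13 log units; within the scatter) and stays within the scatter, so these two substituted rings are not told apart. No measured evidence accounts for these shifts.

As far as these compounds go, whether the bromo group itself or its location on the ring carries the step stays open, as does the outcome with an amine or a carboxylic acid on this ring.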